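Aryl variation on the triazole nitrogen of a spirooxindole series

A few compounds are considered here, and "the series" means these few. Any claim that something is new, unique, unknown or untested is made for them only; others in the source may bear on it.

Measured compounds in an ADME assay on HUVEC cells (Homo sapiens) for antiproliferative activity, read by MTT assay, with a stated time of 48 h; a higher number here means a weaker inhibitor, a lower number a stronger inhibitor:
compound 1 `Cc1ccc(-n2nncc2CN2C(=O)C3(C(C#N)=C(N)Oc4c3c3nc5ccccc5nc3c3ccccc43)c3ccccc32)cc1C` gives > 50000 nM
compound 2 `N#CC1=C(N)Oc2c(c3nc4ccccc4nc3c3ccccc23)C12C(=O)N(Cc1cnnn1-c1cc(Cl)ccc1Cl)c1ccccc12` gives > 50000 nM
compound 3 `Cc1ccccc1-n1nncc1CN1C(=O)C2(C(C#N)=C(N)Oc3c(N)cc4nc5ccccc5nc4c32)c2ccccc21` gives > 50000 nM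

Each of these values is a limit of this assay, not a number. For the measured compounds named here, compound 3 therefore stands at the limit, and the same holds for compound 1 and compound 2; the one step that varies the aryl group on the aromatic nitrogen, a step that the two limits leave unreadable from compound 1 to compound 2, is unreadable because both ends sit at the limit (the limit of > 50000 nM in this assay, at which 3 of the 3 values shown sit).

Compound 4 `N#CC1=C(N)Oc2c(N)cc3nc4ccccc4nc3c2C12C(=O)N(Cc1cnnn1-c1cccc(C(F)(F)F)c1)c1ccccc12` differs from compound 3 by 3-(trifluoromethyl)phenyl in place of 2-methylphenyl on an aromatic nitrogen. Going by the values given here, this is the same kind of change as the one from compound 1 to compound 2, and that step gave no readable size. Among the compounds with values here, no measured step therefore points to any direction for compound 4 in this assay.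

Compound 4 is expected to remain at the limit as well, with an estimated value of 50000 nM (range 20000 nM to 200000 nM), which corresponds to an expected step of a number no higher from compound 3 to compound 4 (the limit leaves the size open) from compound 3, that is none beyond the scatter.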

Compound 4, half-maximal inhibitory concentration: > 50000 nM
Compound 4: only a limit was reported (the forecaster's own chance of this, stated with the estimate: 85%); the middle value sits exactly at the limit.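

No new step can be read in this assay from compound 3 to compound 4, because both compounds give limits rather than numbers: the limit of > 50000 nM in this assay, at which 4 of the 4 values shown sit. The compounds shown leave open how the aryl group on the aromatic nitrogen bears on activity in this assay.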